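Adding chloro to compound 1

The source may hold more compounds than are shown below. What is called first, only, known or untested is meant among the compounds shown, and "the series" means these compounds.

Of the compounds shown here, two have measured values so far. In a functional assay on KARPAS-299 cells (Homo sapiens) for inhibition, read by CellTiter-Glo, with a stated time of 96 h (on this read-out higher numbers stand for weaker inhibition and lower numbers for stronger inhibition), compound 1 `CC(C)S(=O)(=O)c1nn(C)cc1Nc1nc(Nc2ccc(C3CCN(C)CC3)cc2OC2CC2)ncc1Cl` gives 7 nM. In this assay compound 2 `Cc1cc(Nc2ncc(Cl)c(Nc3cn(C)nc3S(=O)(=O)C(C)C)n2)c(OC(C)C)cc1C1CNC1` gives 60 nM. Compound 1 holds the lower of the two numbers, which means the stronger inhibition, and the gap between them lies beyond the scatter. Within the data shown here, the two compounds differ in more than one place, so no measured single-place step is available.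

The next compound, compound 3 `CC(C)S(=O)(=O)c1nn(C)cc1Nc1nc(Nc2cc(Cl)c(C3CCN(C)CC3)cc2OC2CC2)ncc1Cl`, keeps the core of compound 1 and changes it in one place: chloro in place of hydrogen on an aromatic carbon. This is chloro in place of hydrogen on an aromatic carbon, ortho to a 1-methylpiperidin-4-yl group and para to a cyclopropyloxy group.

Among the measured compounds shown here, the series holds no measured example of this change, so the expectation starts from the 7 nM of compound 1 and the range is kept wide. The expected result in this assay is a 1.4-fold higher number from compound 1 to compound 3 (0.15 log units; within the scatter), a small rise that is not expected to pass beyond the scatter. For compound 3 the estimated value is 10 nM, with an expected range from 3 nM to 35 nM.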

Compound 3, half-maximal inhibitory concentration: 15 nM
Beside the measured number, compound 3's estimate is 1.5-fold (0.18 log units) below it, and the stated range covers the measured number.
By their numbers in this assay, from the lowest: compound 1; then compound 3; then compound 2.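

In this assay, among these compounds, chloro in place of hydrogen on this aromatic carbon, ortho to a 1-methylpiperidin-4-yl group and para to a cyclopropyloxy group, gives the first single-place step: a 2.1-fold higher number from compound 1 to compound 3 (0.33 log units; beyond the scatter). The direction is toward weaker inhibition, and the size is modest. This position therefore responds to substitution, since the chloro group alone moves the number beyond the scatter, yet the change still leaves inhibition in the range of compound 3 at 15 nM. No available data give a reason for this step.

With chloro as the only group shown at this carbon, one step cannot tell whether the rise belongs to chloro in particular or would follow with any group here, and fluoro, methyl, methoxy or a nitrile at the same carbon would test that. Among the compounds shown here, it also remains open whether the same change gives a step of similar size when the surrounding groups are those of compound 2, as the series holds no matching pair for that comparison.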